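A few compounds are considered here, and "the series" means these few. Any claim that something is new, unique, unknown or untested is made for them only; others in the source may bear on it.

Measured so far in a functional assay on NCI-H727 cells (Homo sapiens) for antiproliferative activity, with a stated time of 48 h (a higher number here means a weaker inhibitor, a lower number a stronger inhibitor), each value a limit of the assay:
- Compound 1 `CCN(CC)c1ccc(-c2ccc(C#N)cc2)nn1`: > 25000 nM
- Compound 2 `CCOC(=O)c1ccc(-c2ccc(N(C)C)nn2)cc1`: > 25000 nM
- Compound 3 `COC(=O)c1ccc(-c2ccc(N(C)C)nn2)cc1`: > 25000 nM

Compound 2 gives no number, only the limit > 25000 nM. The other two compounds fare no differently, so the whole set rests on (the limit of > 25000 nM in this assay, at which 3 of the 3 values shown sit).

Compound 4 `CCCCOc1ccc(-c2ccc(C(=O)OCC)cc2)nn1` differs from compound 2 at one place, with butoxy in place of dimethylamino on an aromatic carbon. Among the compounds with values here, the one measured step, a step that the two limits leave unreadable from compound 2 to compound 3, concerns a different place in the structure and has no readable size. Within the data shown here, no measured step makes this exchange of groups, so no size can be carried over. In this assay, no step beyond the scatter is expected in either direction.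

This expectation starts from compound 2, whose limit is > 25000 nM. The expected change is a step that the limit leaves unreadable from compound 2 to compound 4, and it is an estimate only. Compound 4 is estimated at 30000 nM, with an expected range from 10000 nM to 60000 nM.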

Compound 4, half-maximal inhibitory concentration: > 25000 nM
Compound 4: a limit, no number (the forecaster's own chance of this, stated with the estimate: 70%); the middle value is on the limit's open side.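

Compound 4, like compound 2, gives only a limit in this assay, so no step can be read between these two compounds. The compounds shown leave open whether butoxy or dimethylamino at this place changes activity at all, since every value is the same limit: the limit of > 25000 nM in this assay, at which 4 of the 4 values shown sit.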